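The compounds below may be only part of what the source reports. "The series", "measured", "known", "first", "only" and "open" are said of these compounds alone.

Measured compounds:
compound 1 `O=C1N=C(N2N=C(c3ccccc3)CC2c2ccccc2O)S/C1=C1/C(=O)Nc2ccccc21`, 3190 nM;
compound 2 `COc1ccc(C2CC(c3ccccc3)=NN2C2=NC(=O)/C(=C3\C(=O)Nc4ccccc43)S2)cc1`, 1640 nM;
compound 3 `COc1ccc(C2CC(c3ccccc3)=NN2C2=NC(=O)/C(=C3\C(=O)Nc4ccc(Br)cc43)S2)cc1`, 250 nM.

These three compounds share one core and were tested in a functional assay on cells (Leukemia cell, Homo sapiens) for cytotoxicity, read by sulforhodamine B assay, with a stated time of 48 h; a lower number here means a stronger inhibitor of growth, a higher number a weaker inhibitor of growth. Compound 2 stands second highest of the three numbers: its nearest neighbour is compound 1, a step of a 1.9-fold lower number from compound 1 to compound 2 (0.29 log units; within the scatter), while compound 3 lies furthest from it, a step of a 6.6-fold lower number from compound 2 to compound 3 (0.82 log units; beyond the scatter).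

Compound 4 `COc1ccc(C2CC(c3ccc4ccccc4c3)=NN2C2=NC(=O)/C(=C3\C(=O)Nc4ccccc43)S2)cc1` has not yet been measured. It differs from compound 2 in one place: naphthalen-2-yl in place of phenyl on a carbon with a double bond to nitrogen. Neither measured step touches this position. The step from compound 1 to compound 2 changed the group on the saturated ring carbon and stayed within the scatter; the step from compound 2 to compound 3 added bromo on an aromatic carbon of the other part of the core and gave a modest gain. Nothing measured here speaks to the carbon with a double bond to nitrogen. The expectation for compound 4 is therefore a step of a 1.3-fold lower number from compound 2 to compound 4 (0.10 log units; within the scatter), which is no step beyond the scatter. Compound 4 is estimated to give 1300 nM in this assay, expected to fall between 400 nM and 4000 nM.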

Compound 4, concentration for 50% growth inhibition: 17500 nM
Compound 4: middle estimate off by 13-fold (1.13 log units), on the low side, outside the stated range (above it).
By their numbers in this assay, from the lowest: compound 3; then compounds 2 and 1 (each within the scatter of the next); then compound 4.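

For the compounds shown here, the carbon with a double bond to nitrogen, which no earlier step had touched, turns out to matter for growth inhibition: in this assay, the change from phenyl to naphthalen-2-yl gives an 11-fold higher number from compound 2 to compound 4 (1.03 log units; beyond the scatter). The change enlarges the group at this position from one six-membered aromatic ring to two, from 6 to 10 heavy atoms, while adding no hydrogen-bond donor or acceptor and no net charge, so the loss comes with added carbon rings alone, at least in this single pair. It also runs opposite in direction to the gain seen with bromo on the other part of the core, showing that the shared core does not respond to every aromatic change in the same way, and the material at hand offers no measured reason for the loss.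

The compounds shown leave open whether any group at this carbon improves on phenyl, for instance a methyl, a pyridyl ring or a phenyl carrying a dimethylamino group. They also leave open whether naphthalen-2-yl carries the same penalty when the bromo of compound 3 is present on the core.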